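Working notes: sulfur-linked five-membered ring swap on compound 1

The source may hold more compounds than are shown below. What is called first, only, known or untested is meant among the compounds shown, and "the series" means these compounds.

Measured compounds. Compound 1 `Cc1nnc(SCc2cc(=O)c3ccccc3o2)o1` gives in a functional assay on HeLa cells (Homo sapiens) for cytotoxicity, read by MTT assay, with a stated time of 72 h (on this read-out higher numbers stand for weaker inhibition and lower numbers for stronger inhibition), a value of > 25000 nM, which is a limit of the assay and not a number. Compound 2 `O=c1cc(CSc2nc3ccccc3s2)oc2ccc(Cl)cc12` gives in this assay > 25000 nM, likewise a limit. Compound 3 `Cc1cc(C)n2nc(SCc3nnc(SCc4coc5ccccc5c4=O)n3N)nc2n1` gives in this assay > 25000 nM, again a limit.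

Where compound 1 stands: it sits at the limit of > 25000 nM in this assay, at which 3 of the 3 values shown sit. Within the data shown here, no measured value separates compound 1 from compound 2 or compound 3, and no step between measured compounds is available, so nothing anchors the size of any change.

The unmeasured compound 4 `Cc1nnc(SCc2cc(=O)c3ccccc3o2)s1` differs from compound 1 by 5-methyl-1,3,4-thiadiazol-2-yl in place of 5-methyl-1,3,4-oxadiazol-2-yl on a sulfur. The leaving and entering groups match in what is counted, and the place on the sulfur is the same.

With only limits to go on, the step is expected to be none beyond the scatter: the expected step from compound 1 to compound 4 is a step that the limit leaves unreadable from compound 1 to compound 4. Compound 4 is therefore estimated at 30000 nM, with a range from 10000 nM to 100000 nM, and it is expected that this assay will most likely again report only a limit.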

Compound 4, half-maximal inhibitory concentration: > 25000 nM
Compound 4 was reported as a limit (the forecaster's own chance of this, stated with the estimate: 80%); the middle value lies beyond the limit too.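

No step can be read from compound 1 to compound 4, since both values are limits of the assay and not numbers: the limit of > 25000 nM in this assay, at which 4 of the 4 values shown sit.

The compounds shown leave open whether 5-methyl-1,3,4-thiadiazol-2-yl in place of 5-methyl-1,3,4-oxadiazol-2-yl on a sulfur changes the read-out in this assay at all.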